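From piperidin-4-yl to 4-chlorophenyl on a shared core

This account rests on a few compounds, and the source may have more. Where it says the series, first, only, none or still open, it means among the compounds named here.

Among the measured compounds shown here, in a functional assay on MDA-MB-231 cells (Homo sapiens) for antiproliferative activity, read by MTT assay, with a stated time of 24 h (a higher number here means a weaker inhibitor, a lower number a stronger inhibitor), compound 1 `COc1ccc(-c2noc(C3CCNCC3)n2)cc1OC1CCCC1` gives 370 nM, the only actual number so far. Compound 2 `COc1ccc(-c2noc(Cc3c[nH]c4ccccc34)n2)cc1OC1CCCC1` gives > 1000000 nM, which is a limit of the assay. Compound 3 `COc1cc(-c2noc(-c3ccncc3)n2)ccc1OCc1ccccc1` gives > 1000000 nM, again a limit. Compound 4 `COc1ccc(-c2noc(-c3ccc(Cl)cc3)n2)cc1OC1CCCC1` keeps the core of compound 1 but carries 4-chlorophenyl in place of piperidin-4-yl on an aromatic carbon. For the measured compounds named here, no measured pair isolates this change, so the expectation rests on little. Only compound 1 carries piperidin-4-yl, and the other evidence is the limit of > 1000000 nM in this assay, at which 2 of the 3 values shown sit. The expected change is a 54-fold higher number from compound 1 to compound 4 (1.73 log units; beyond the scatter), a large step towards weaker inhibition in this assay. Compound 4 is estimated at 20000 nM, with an expected range from 1000 nM to 500000 nM.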

Compound 4, half-maximal inhibitory concentration: 396000 nM
Compound 4: the middle estimate sits 20-fold (1.30 log units) below what was measured; the range from low to high includes it.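

Among the compounds shown here, on this aromatic carbon of the shared core, 4-chlorophenyl in place of piperidin-4-yl gives a 1100-fold higher number from compound 1 to compound 4 (3.03 log units; beyond the scatter) in this assay, the first step between measured compounds that differ in one place. The group on this carbon therefore matters greatly for compound 1, and compound 4 still gives a number, so the step has a size: the limit of > 1000000 nM in this assay, at which 2 of the 4 values shown sit.

One pair cannot separate the removal of piperidin-4-yl from the arrival of 4-chlorophenyl. On these data alone, how an unsubstituted phenyl, a piperazine or an open-chain amine would read on this carbon remains open.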